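The compounds below may be only part of what the source reports. "The series", "measured", "known", "first", "only" and "open" are said of these compounds alone.

In a functional assay on HepG2 cells (Homo sapiens) for inhibition, read by MTT assay, with a stated time of 24 h (on this read-out lower numbers stand for stronger inhibition and higher numbers for weaker inhibition), compound 1 (`Cc1ccc(C(=O)NCC(=O)N/N=C/c2cccc(OCc3ccccc3Cl)c2)cc1`) gives 47500 nM and stands within the scatter of both other measured compounds. Compound 2 (`O=C(CNC(=O)c1ccc(F)cc1)N/N=C/c1ccccc1OCc1ccccc1Cl`) at 24900 nM and compound 3 (`Cc1ccc(C(=O)NCC(=O)N/N=C/c2ccc(OCc3ccccc3Cl)cc2)cc1`) at 28100 nM lie so close to it, and to each other, that the three cannot be ranked. Compound 4 (`O=C(CNC(=O)c1cccnc1Cl)N/N=C/c1cccc(OCc2ccccc2Cl)c1`) has not yet been measured. It differs from compound 1 in one place, with 2-chloropyridin-3-yl in place of 4-methylphenyl on a carbonyl carbon. Going by the values given here, no two measured compounds differ in only one place, so the data hold no direct measure of such a change. With compound 1 at 47500 nM and compound 2 at 24900 nM within the scatter of each other, no step beyond the scatter is expected in this assay from this change. The expected step (a 1.5-fold lower number from compound 1 to compound 4 (0.17 log units; within the scatter)) stays within the scatter. Compound 4 is estimated at 32000 nM (expected range from 13000 nM to 75000 nM).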

Compound 4, half-maximal inhibitory concentration: 3100 nM
For compound 4 the middle estimate is 10-fold (1.01 log units) above the measured one; the measured number lies below the stated range.
By their numbers in this assay, from the lowest: compound 4; then compounds 2, 3 and 1 (each within the scatter of the next).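

In this assay, going by these compounds alone, replacing 4-methylphenyl with 2-chloropyridin-3-yl on the carbonyl carbon gives a 15-fold lower number from compound 1 to compound 4 (1.19 log units; beyond the scatter), so this position, unlike anything the earlier compounds could show, has a direct measure of a change large enough to stand clear of the scatter. The two groups have the same count of heavy atoms and each has one six-membered aromatic ring, so the step comes with a swap in ring and substituent atoms rather than a change in heavy-atom count. Nothing available explains the size of this step.

The ring nitrogen and the chlorine enter together, so the compounds shown cannot say whether either alone would carry the step, as a plain pyridin-3-yl or a 2-chlorophenyl group would test. The step also rests on a single pair, leaving open whether a 2-methoxypyridin-3-yl group would behave alike.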